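Working notes: from compound 2 to compound 3

The source may hold more compounds than are shown below. What is called first, only, known or untested is meant among the compounds shown, and "the series" means these compounds.

Measured in a functional assay on HepG2 cells (Homo sapiens) for antiproliferative activity, read by MTT assay, with a stated time of 48 h; on this read-out lower numbers stand for stronger inhibition and higher numbers for weaker inhibition:
- compound 1 `CN(C)c1ccc(NC(=O)Nc2cccc(CNc3nccnc3Cl)c2)cc1`: > 40000 nM (a limit, not a number)
- compound 2 `O=C(Nc1cccc(Cl)c1)Nc1cccc(CNc2nccnc2Cl)c1`: 9140 nM

For the measured compounds named here, compound 2, at 9140 nM, holds the only true number so far. The value of compound 1 is a limit: the limit of > 40000 nM in this assay, at which 1 of the 2 values shown sits.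

Compound 3 `Cc1ccc(NC(=O)Nc2cccc(CNc3nccnc3Cl)c2)c(C)c1` carries 2,4-dimethylphenyl in place of 3-chlorophenyl on an amide-type nitrogen.

Going by the values given here, one measured step bears on this, at the same place: an at least 4.3-fold lower number from compound 1 to compound 2 (0.64 log units; beyond the scatter). It lies beyond the scatter, so the group on this nitrogen can move the number, but it rests on a single pair and gives no firm size. The group that leaves here is the one that gave the lower number in that step, so a modest move towards a higher number in this assay is expected, near the edge of the scatter. The expected step is a 1.9-fold higher number from compound 2 to compound 3 (0.27 log units; within the scatter). For compound 3 the estimate is 17000 nM, with an expected range of 5500 nM to 40000 nM.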

Compound 3, half-maximal inhibitory concentration: 9290 nM
The estimate for compound 3 lay 1.8-fold (0.26 log units) above the measured number; the measured number falls inside the stated range.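

In this assay the change reads a 1.0-fold higher number from compound 2 to compound 3 (0.01 log units; within the scatter), so 3-chlorophenyl and 2,4-dimethylphenyl on this amide-type nitrogen cannot be told apart, and a chlorine is not needed on this ring for compound 3 to match compound 2. Against 4-(dimethylamino)phenyl the same group gives an at least 4.3-fold lower number from compound 1 to compound 3 (0.63 log units; beyond the scatter), so among the three compounds only the 4-(dimethylamino)phenyl compound stands apart. That step has only a lowest size, as compound 1 carries a limit and not a number: the limit of > 40000 nM in this assay, at which 1 of the 3 values shown sits.

Open, going by these compounds, is how a plain phenyl, or a phenyl bearing a single methyl, would read on this nitrogen, which would show whether either methyl group counts on its own. Also open, on these data alone, is whether a carboxylic acid or a primary amine on this ring would move the number as 4-(dimethylamino)phenyl does.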